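The source may hold more compounds than are shown below. What is called first, only, known or untested is meant among the compounds shown, and "the series" means these compounds.

Measured compounds:
- Compound 1, `CCCCc1nc(C(C)C)c(CC(=O)OCCC)c(=O)n1Cc1ccc(-c2ccccc2-c2noc(=O)[nH]2)cc1`: 7.2%
- Compound 2, `CCCCOC(=O)Cc1c(C(C)C)nc(CCCC)n(Cc2ccc(-c3ccccc3-c3noc(=O)[nH]3)cc2)c1=O`: 7.1%

Both were tested in an ADME assay on microsomes from liver (Homo sapiens) for metabolic stability, with a stated time of 30 min; on this read-out lower numbers stand for a less stable compound and higher numbers for a more stable compound. Among the compounds with values here, compound 2 stands beside compound 1, and the only step between them, a number 0.1 percentage points lower from compound 1 to compound 2 (within the scatter), is a change too small to count. Compound 3, `CC#CCOC(=O)Cc1c(C(C)C)nc(CCCC)n(Cc2ccc(-c3ccccc3-c3noc(=O)[nH]3)cc2)c1=O`, has not been measured yet. It differs from compound 2 in one place: prop-1-yn-1-yl in place of propyl on a saturated chain carbon bound to an oxygen next to a carbonyl group. Within the data shown here, no measured step covers this kind of change; the single step that exists, from compound 1 to compound 2, swaps one saturated chain piece for another and is within the scatter. On that thin basis no step beyond the scatter is expected for compound 3 in this assay, so the expected step of a number 0.9 percentage points higher from compound 2 to compound 3 (within the scatter) is small. Compound 3 is therefore estimated to give 8% in this assay, with a range from 2% to 20%.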

Compound 3, percent of the compound remaining: 13.7%
Compound 3: middle estimate off by 5.7 percentage points, on the low side; the range from low to high includes it.
By their numbers in this assay, from the lowest: compounds 2, 1 and 3 (each within the scatter of the next).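

In this assay, within the data shown here, this is the first look at a triple bond at this position: prop-1-yn-1-yl in place of propyl, on a saturated chain carbon bound to an oxygen next to a carbonyl group, gives a number 6.6 percentage points higher from compound 2 to compound 3 (within the scatter). With ethyl as the group replaced, the comparison reads a number 6.5 percentage points higher from compound 1 to compound 3 (within the scatter). So neither the triple bond nor these changes in the saturated chain produce a step beyond the scatter, and no information here explains the numbers.

As far as these compounds go, it remains open whether an amine, a carboxylic acid or a longer chain at this position would move the read-out beyond the scatter. The compounds shown also leave open whether a triple bond would behave the same way elsewhere on the shared core.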